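A few compounds are considered here, and "the series" means these few. Any claim that something is new, unique, unknown or untested is made for them only; others in the source may bear on it.

Measured so far in a functional assay on HUVEC cells (Homo sapiens) for inhibition, tested at 5 ug/mL; a higher number here means a stronger effect of the compound at the concentration tested, a lower number a weaker effect:
Compound 1, `COc1cc(/C=C/C(=O)c2cccc(NC(=O)c3c(Cl)cccc3Cl)c2)ccc1O`, gives 88%.
Compound 2, `COc1cc(/C=C/C(=O)c2cccc(NC(=O)c3cc(Cl)cc(Cl)c3)c2)ccc1O`, gives 51%.
Compound 3, `COc1cc(/C=C/C(=O)c2cccc(NC(=O)c3ccc(Cl)cc3Cl)c2)ccc1O`, gives 51%.

Compound 3 is level with compound 2, and the two share the lowest value of the three; compound 1 stands well above, as the step of a number 37 percentage points lower from compound 1 to compound 3 (beyond the scatter) shows. Compound 4, `COc1cc(/C=C/C(=O)c2cccc(NC(=O)c3ccc(Cl)c(Cl)c3)c2)ccc1O`, differs from compound 3 in one place: 3,4-dichlorophenyl in place of 2,4-dichlorophenyl on a carbonyl carbon. The measured steps that bear on such a shift of the two chlorines within the ring are a number 37 percentage points lower from compound 1 to compound 2 (beyond the scatter) and a number 37 percentage points lower from compound 1 to compound 3 (beyond the scatter), both large, and no change at the digits printed from compound 2 to compound 3 (within the scatter), which stayed within the scatter. Going by the values given here, since the only step between two rings lacking the 2,6-dichlorophenyl pattern showed no change, the expectation is a step of about no change at the digits printed from compound 3 to compound 4 (within the scatter). Compound 4 is therefore estimated at 51%, with a likely range from 33% to 70%.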

Compound 4, a percentage reported as inhibition, at one concentration (the size of the read-out at that concentration, not a potency): 5%
Beside the measured number, compound 4's estimate is 46 percentage points above it; the measured number lies below the stated range.
By their numbers in this assay, from the lowest: compound 4; then compounds 2 and 3 (each within the scatter of the next); then compound 1.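

In this assay, moving the chlorines on the ring attached to the carbonyl carbon gives a number 46 percentage points lower from compound 3 to compound 4 (beyond the scatter) and a number 46 percentage points lower from compound 2 to compound 4 (beyond the scatter). Compound 2 and compound 3 sit level, so the equal values of those two hid how much the chlorine pattern can matter. The 3,4-dichlorophenyl ring also gives a number 83 percentage points lower from compound 1 to compound 4 (beyond the scatter) and stands lowest of the four, so rings lacking the 2,6-dichlorophenyl pattern do not all read alike. Nothing available here explains this difference. Still open, on these data alone, is how a ring with a single chlorine, a methyl group or an amine would read at this place.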